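Cyano for Trifluoromethyl on the Benzyl Piperazine

This account rests on a few compounds, and the source may have more. Where it says the series, first, only, none or still open, it means among the compounds named here.

Of the compounds shown here, two have been measured. In a functional assay on MCF7 cells (Homo sapiens) for cytotoxicity, read by MTT assay, with a stated time of 48 h (on this read-out higher numbers stand for weaker inhibition and lower numbers for stronger inhibition), compound 1 `CCN(CC)c1ccc2cc(C(=O)c3ccc(N4CCN(C(=O)CN5CCN(S(=O)(=O)c6ccc(F)cc6)CC5)CC4)cc3)oc2c1` gives 20500 nM, and compound 2 `CCN(CC)c1ccc2cc(C(=O)c3ccc(N4CCN(C(=O)CN5CCN(Cc6ccc(C(F)(F)F)cc6)CC5)CC4)cc3)oc2c1` gives 18200 nM. For the measured compounds named here, the one step between them, a 1.1-fold lower number from compound 1 to compound 2 (0.05 log units; within the scatter), exchanged the whole substituent on the ring amine nitrogen, and the two numbers fall within the scatter of each other, so compound 2 stands level with compound 1 rather than apart from it.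

Compound 3 `CCN(CC)c1ccc2cc(C(=O)c3ccc(N4CCN(C(=O)CN5CCN(Cc6ccc(C#N)cc6)CC5)CC4)cc3)oc2c1` differs from compound 2 by cyano in place of trifluoromethyl on an aromatic carbon. Going by the values given here, no measured step touches this exact exchange; the only step known, a 1.1-fold lower number from compound 1 to compound 2 (0.05 log units; within the scatter), altered a far larger portion of the same region without moving the number beyond the scatter. One therefore expects the smaller change to compound 3 to produce a 1.1-fold higher number from compound 2 to compound 3 (0.04 log units; within the scatter), that is, no shift beyond the scatter in either direction. Compound 3 is estimated at 20000 nM, with a range from 8000 nM to 50000 nM.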

Compound 3, half-maximal inhibitory concentration: > 40000 nM
Compound 3 was reported as a limit (the forecaster's own chance of this, stated with the estimate: 5%); at least 2.0-fold (0.30 log units) between middle value and limit.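

The exchange of trifluoromethyl for cyano, on an aromatic carbon para to a large group, gives an at least 2.1-fold higher number from compound 2 to compound 3 (0.34 log units; beyond the scatter), so this small change to the 4-(trifluoromethyl)benzyl group moves the number beyond the scatter, unlike the exchange of the whole substituent, a 1.1-fold lower number from compound 1 to compound 2 (0.05 log units; within the scatter). The comparison with the sulfonyl compound settles no order, since its floor stays within the scatter: an at least 1.9-fold higher number from compound 1 to compound 3 (0.29 log units; that floor lies within the scatter). In this assay the value of compound 3 is a limit and not a number: the limit of > 40000 nM in this assay, at which 1 of the 3 values shown sits.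

The compounds shown leave open where compound 3 truly stands. They also leave open whether a chlorine atom, a methoxy group or a carboxylic acid at this place would stay level with compound 2 or move away from it as cyano does.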